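The compounds below may be only part of what the source reports. "The series", "measured", "known", "first", "only" and "open" are said of these compounds alone.

Measured compounds: compound 1 `COc1cc(OC)cc(-c2ccc(-c3ccc(C(=N)N)c(F)c3)s2)c1` with 1300 nM; compound 2 `N=C(N)c1ccc(-c2ccc(-c3ccc(F)cc3)s2)cc1` with 1590 nM; compound 3 `N=C(N)c1ccc(-c2ccc(-c3ccc(Cl)cc3)s2)cc1` with 164 nM.

In a functional assay on PC-3 cells (Homo sapiens) for inhibition, read by sulforhodamine B assay, with a stated time of 48 h (a higher number here means a weaker inhibitor of growth, a lower number a stronger inhibitor of growth), compound 1 gives 1300 nM, the second highest of the three numbers. Compound 2 is its nearest neighbour, a gap within the scatter, while compound 3 lies furthest from it, a gap beyond the scatter. Compound 4 `COc1cc(OC)cc(-c2ccc(-c3ccc(C(=N)N)cc3)s2)c1` has not been measured; its change from compound 1 is hydrogen in place of fluoro on an aromatic carbon. Within the data shown here, the only measured step, a 9.7-fold lower number from compound 2 to compound 3 (0.99 log units; beyond the scatter), concerns a different exchange on the other aromatic ring and does not bear on this change, so no measured step tests the loss of fluoro here. The step of a 1.1-fold lower number from compound 1 to compound 4 (0.03 log units; within the scatter) is therefore expected to lie within the scatter. The estimate for compound 4 is 1200 nM, with a range from 400 nM to 4000 nM.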

Compound 4, concentration for 50% growth inhibition: 1800 nM
The estimate for compound 4 lay 1.5-fold (0.18 log units) below the measured number; the measured number falls inside the stated range.
By their numbers in this assay, from the lowest: compound 3; then compounds 1, 2 and 4 (each within the scatter of the next).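

In this assay the exchange gives a small step (a 1.4-fold higher number from compound 1 to compound 4 (0.14 log units; within the scatter)), the first measured at this position. On this aromatic carbon, ortho to a group of 3 heavy atoms, hydrogen and fluoro therefore cannot be told apart with the dimethoxy-bearing compounds. Nothing available accounts for this result.

On these data alone, it remains open whether a nitrile or a trifluoromethyl group on this carbon would shift the number beyond the scatter. Also open, as far as these compounds go, is whether fluoro and hydrogen would stay indistinguishable here alongside the chloro group of compound 3.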